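Removing a Fluorine From a Weak Melanoma Cell Inhibitor

The source may hold more compounds than are shown below. What is called first, only, known or untested is meant among the compounds shown, and "the series" means these compounds.

Two related compounds have been tested in a functional assay on B16-F10 cells (Mus musculus) for cytotoxicity, read by MTT assay, with a stated time of 48 h; a higher number here means a weaker inhibitor, a lower number a stronger inhibitor. Compound 1 `Clc1ccc2nc(Nc3nc4ccccc4s3)sc2c1` gives > 50000 nM, which is a limit of the assay and not a number; it sits at the limit of > 50000 nM in this assay, at which 1 of the 2 values shown sits. Among the compounds with values here, compound 2 `CCOc1ccc2nc(Nc3nc4ccc(F)cc4s3)sc2c1` gives 33200 nM and is the only compound here with a measured number. Compound 3 `CCOc1ccc2nc(Nc3nc4ccccc4s3)sc2c1` differs from compound 2 by hydrogen in place of fluoro on an aromatic carbon. Within the data shown here, no measured pair shows this change, so the step is expected to stay within the usual scatter, leaning slightly weaker. Compound 3 is therefore estimated at 40000 nM, between 15000 nM and 100000 nM. That expectation means a step of a 1.2-fold higher number from compound 2 to compound 3 (0.08 log units; within the scatter).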

Compound 3, half-maximal inhibitory concentration: > 50000 nM
Compound 3 gave a limit, no number (the forecaster's own chance of this, stated with the estimate: 35%); middle value at least 1.2-fold (0.09 log units) away from the limit.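

On this aromatic carbon, hydrogen in place of fluoro gives an at least 1.5-fold higher number from compound 2 to compound 3 (0.17 log units; that floor lies within the scatter) in this assay, so the true size of the change could be small or large. The step with ethoxy in place of chloro cannot be read, as both of its values are limits. The measurable range of this small set is now nearly used up: the limit of > 50000 nM in this assay, at which 2 of the 3 values shown sit.

Going by these compounds, whether an amine or a carboxylic acid on this same carbon would give a lower number remains open. So does the effect of a longer chain in place of ethoxy.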